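A few compounds are considered here, and "the series" means these few. Any claim that something is new, unique, unknown or untested is made for them only; others in the source may bear on it.

Measured so far in a physicochemical assay for solubility, in phosphate buffer, measured as kinetic solubility, with a stated time of 1 h, at pH 7.4; on this read-out higher numbers stand for higher solubility and lower numbers for lower solubility:
Compound 1 `COc1ccc2nc(C)cc(OCC(=O)Nc3ccc(Br)c(C)c3)c2c1` sits at a limit of this assay, < 1000 nM.
Compound 2 `COc1ccc2nc(C)cc(OCC(=O)Nc3cccnc3)c2c1` gives 32000 nM in this assay.
Compound 3 `COc1ccc2nc(C)cc(OCC(=O)Nc3ccncn3)c2c1` gives 27500 nM in this assay.

Compound 3 holds the lower of the two numbers, and the step of a 1.2-fold lower number from compound 2 to compound 3 (0.07 log units; within the scatter) lies within the scatter; the remaining value is a limit, (the limit of < 1000 nM in this assay, at which 1 of the 3 values shown sits). Compound 4 `COc1ccc2nc(C)cc(OCC(=O)NNC(=O)c3ccncc3)c2c1` differs from compound 3 by ((pyridin-4-yl)carbonyl)amino in place of pyrimidin-4-yl on an amide-type nitrogen. Within the data shown here, two measured steps bear on this: exchanging one six-membered heteroaryl for another gave a 1.2-fold lower number from compound 2 to compound 3 (0.07 log units; within the scatter), while moving away from the 4-bromo-3-methylphenyl gave an at least 27-fold higher number from compound 1 to compound 3 (1.43 log units; beyond the scatter). Since the entering group keeps a six-membered aromatic ring with one hetero atom and adds a hydrogen-bond donor, no step beyond the scatter is expected. For compound 4 the expected change is a 1.1-fold lower number from compound 3 to compound 4 (0.04 log units; within the scatter), an estimate of 25000 nM with a range from 8000 nM to 80000 nM.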

Compound 4, solubility: >= 375000 nM
Compound 4 gave a limit, no number; the forecaster's own chance of this, stated with the estimate: 10%; middle value at least 15-fold (1.17 log units) from the limit.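

In this assay compound 4 gives a limit and not a number: the limit of >= 375000 nM in this assay, at which 1 of the 4 values shown sits.

At this amide-type nitrogen, ((pyridin-4-yl)carbonyl)amino stands apart from both directly attached heteroaryl groups, with an at least 13-fold higher number from compound 3 to compound 4 (1.13 log units; beyond the scatter) and an at least 11-fold higher number from compound 2 to compound 4 (1.06 log units; beyond the scatter), whereas pyrimidin-4-yl and pyridin-3-yl lay within the scatter of each other. Replacing 4-bromo-3-methylphenyl gives the widest step, an at least 370-fold higher number from compound 1 to compound 4 (2.57 log units; beyond the scatter).

The compounds shown leave open whether this step belongs to the carbonyl, the added amino nitrogen or the pyridin-4-yl ring. A benzoylamino or acetylamino group at the same nitrogen would separate these parts.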